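Fluoro for hydrogen in a series at the assay limit

This account rests on a few compounds, and the source may have more. Where it says the series, first, only, none or still open, it means among the compounds named here.

Compound 1 `C[C@]1(CO)OCC(n2ccc(N)nc2=O)O1` was tested in a functional assay on CCRF-CEM cells (Homo sapiens) for inhibition; on this read-out lower numbers stand for stronger inhibition and higher numbers for weaker inhibition. For compound 1 the result is a limit of the assay, > 100000 nM. Compound 2 `C[C@]1(CO)OCC(n2cc(F)c(N)nc2=O)O1` differs from compound 1 by one change, (fluoro in place of hydrogen on an aromatic carbon). For compound 2 the result is likewise a limit, > 100000 nM. The step that the two limits leave unreadable from compound 1 to compound 2 cannot be sized, a consequence of the limit of > 100000 nM in this assay, at which 3 of the 3 values shown sit.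

Compound 3 `CC1(CO)OC[C@@H](n2ccc(N)nc2=O)O1` has the same atoms and bonds as compound 1; the two cores differ in this way: the two compounds have the same atoms and bonds; at least one stereo element is drawn with a configuration in one of them and without one in the other: 2 of 2 stereo elements differ; a stereocentre at a saturated ring carbon is drawn S in compound 1 and without a configuration in compound 3; a stereocentre at a saturated ring carbon is drawn without a configuration in compound 1 and S in compound 3. For compound 3 the result is again a limit, > 100000 nM. The step that the two limits leave unreadable from compound 1 to compound 3 is equally unreadable, given the limit of > 100000 nM in this assay, at which 3 of the 3 values shown sit, together with the fact that one of compounds 1 and 3 is drawn with a defined configuration and the other without, at the place where they differ.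

Compound 4 `CC1(CO)OC[C@@H](n2cc(F)c(N)nc2=O)O1` is compound 3 carrying the same change that led from compound 1 to compound 2, namely (fluoro in place of hydrogen on an aromatic carbon); the place of the change is the same in both pairs. In this assay this assay compound 4 is expected to show a step that the limit leaves unreadable from compound 3 to compound 4, because the same change gave a step that the two limits leave unreadable from compound 1 to compound 2 and every measured compound sits at the limit of > 100000 nM in this assay, at which 3 of the 3 values shown sit. Compound 4 is accordingly estimated at about 150000 nM, most likely reported only as a limit, with an expected range from 50000 nM to 500000 nM.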

Compound 4, half-maximal inhibitory concentration: > 100000 nM
Compound 4: no number, only a limit (the forecaster's own chance of this, stated with the estimate: 85%); the middle value does not contradict the limit.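

In this assay compound 4 gives > 100000 nM as a limit of the assay. Neither the step from compound 3 to compound 4 nor the step from compound 2 to compound 4 can be read, because of this: the limit of > 100000 nM in this assay, at which 4 of the 4 values shown sit. The compounds shown leave open whether in this assay fluoro in place of hydrogen or the drawn configuration makes any difference to inhibition.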